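A few compounds are considered here, and "the series" means these few. Any claim that something is new, unique, unknown or untested is made for them only; others in the source may bear on it.

Measured compounds:
- compound 1 `CCNc1nc(-c2ccccc2)nc2c1nnn2Cc1ccccc1F`: 11 nM in an assay on Cerebral cortex for displacement of a labelled ligand from adenosine receptor A1 (Bos taurus); on this read-out lower numbers stand for stronger inhibition and higher numbers for weaker inhibition
- compound 2 `CCNc1nc(-c2ccccc2)nc2c1nnn2Cc1ccccc1C(F)(F)F`: "not determined" (no result reported) in this assay

Among the measured compounds shown here, compound 1 is the only member of the series with a number; compound 2 gives no figure to compare it with, so compound 1 stands alone and no step between measured compounds can be drawn.

Compound 3 `Fc1ccccc1Cn1nnc2c(NC3CCCCC3)nc(-c3ccccc3)nc21` is not yet measured. It differs from compound 1 by cyclohexyl in place of ethyl on a nitrogen on an aromatic ring, with the rest of the shared core unchanged. For the measured compounds named here, with no measured step to lean on, the expectation rests on compound 1 alone, which in this assay gives 11 nM. The step of a 2.2-fold lower number from compound 1 to compound 3 (0.34 log units; beyond the scatter) is expected to be modest and toward stronger inhibition, of a size that may not clear the usual scatter. Compound 3 is therefore estimated at 5 nM, within a range of 1.5 nM to 25 nM.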

Compound 3, inhibition constant: 1.15 nM
Compound 3: middle estimate off by 4.3-fold (0.64 log units), on the high side; measured number below the stated range.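

In this assay, the change from ethylamino to cyclohexylamino gives a 9.6-fold lower number from compound 1 to compound 3 (0.98 log units; beyond the scatter). Among the compounds shown here, this is the first measured step, and it shows that this nitrogen accepts a cyclohexyl group in place of ethyl, with stronger inhibition and the rest of the shared core unchanged. Nothing available here gives a reason for the size of this step.

From the compounds shown here alone, a single step cannot separate the effect of the ring from that of the added carbon count, so it remains open whether the gain belongs to the ring itself. Cyclopentyl, a straight hexyl chain or phenyl on the same nitrogen would bear on that question, and a hydroxyl on the cyclohexyl ring would show whether the ring accepts further substitution.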